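Cyano at the aryl position: a step into untested ground

The compounds below may be only part of what the source reports. "The series", "measured", "known", "first", "only" and "open" are said of these compounds alone.

Compound 1 `Cc1cccc(-n2c(C)cc(C(=O)O)c2C)c1` gives 1500 nM in an assay on cells for inhibition of Palmitoleoyl-protein carboxylesterase NOTUM variant C330S (Homo sapiens), read by fluorescence, with a stated time of 40 min; on this read-out higher numbers stand for weaker inhibition and lower numbers for stronger inhibition.
Compound 2 `Cc1cc(C(=O)O)c(C)n1-c1cccc(Cl)c1` gives 430 nM in this assay.
Compound 3 `Cc1cc(C(=O)O)c(C)n1-c1cccc(C(C)C)c1` gives 360 nM in this assay.

Compound 3 holds the lowest of the three numbers, though a 1.2-fold lower number from compound 2 to compound 3 (0.08 log units; within the scatter) is within the scatter, so compound 2 and compound 3 are not separable; a 4.2-fold lower number from compound 1 to compound 3 (0.62 log units; beyond the scatter) is beyond it. Compound 4 `Cc1cc(C(=O)O)c(C)n1-c1cccc(C#N)c1` differs from compound 3 by cyano in place of isopropyl on an aromatic carbon. Among the compounds with values here, no measured step covers a cyano group. The nearest guidance is a 3.5-fold lower number from compound 1 to compound 2 (0.54 log units; beyond the scatter) and a 4.2-fold lower number from compound 1 to compound 3 (0.62 log units; beyond the scatter), both lowering the number relative to methyl. Within the data shown here, a cyano group has no measured precedent here, so compound 4 is expected to show a modest rise, a 2.5-fold higher number from compound 3 to compound 4 (0.40 log units; beyond the scatter), and its estimated value is 900 nM with a range from 300 nM to 2700 nM.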

Compound 4, half-maximal inhibitory concentration: 3100 nM
Estimate against measurement, compound 4: 3.4-fold (0.54 log units) below, and the stated range ends below it.
By their numbers in this assay, from the lowest: compounds 3 and 2 (each within the scatter of the next); then compound 1; then compound 4.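

In this assay, within the data shown here, cyano is the first group at this position to give a higher number than methyl, with a 2.1-fold higher number from compound 1 to compound 4 (0.32 log units; beyond the scatter), so replacing methyl here does not always lower the number. The gap is wider against the other two groups, with a 7.2-fold higher number from compound 2 to compound 4 (0.86 log units; beyond the scatter) and an 8.6-fold higher number from compound 3 to compound 4 (0.94 log units; beyond the scatter), so cyano stands apart from chloro and isopropyl, which lie within the scatter of each other. Nothing available here bears on why cyano differs from these groups.

From the compounds shown here alone, it remains open whether an amine or a methoxy group at this aromatic carbon would fall with cyano or with chloro and isopropyl.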